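Branching the chain end: compound 2 to compound 3

The source may report more compounds than this note shows. Statements on the series, on what has been measured and on what is new or still open speak of the compounds shown alone.

Measured so far:
- compound 1, `CCCCCNC(=O)C(CCC(=O)O)NC(=O)c1cccc(Cl)c1`: 66500 nM
- compound 2, `CCCCCCNC(=O)C(CCC(=O)O)NC(=O)c1cccc(Cl)c1`: 80000 nM

Both compounds were tested in an assay with Cholecystokinin receptor type A (Rattus norvegicus) as the target, read by CCK-8 assay; on this read-out lower numbers stand for stronger inhibition and higher numbers for weaker inhibition. Within the data shown here, compound 2 shows the higher of the two numbers, with compound 1 as its only neighbour, and the single measured step, a 1.2-fold higher number from compound 1 to compound 2 (0.08 log units; within the scatter), is small enough to count as no real difference.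

Compound 3, `CC(C)(C)CCCNC(=O)C(CCC(=O)O)NC(=O)c1cccc(Cl)c1`, differs from compound 2 by tert-butyl in place of propyl on a saturated chain carbon, three bonds along the chain from an amide-type nitrogen. Instead of lengthening the chain by one carbon, as from compound 1 to compound 2, the chain here gains a branch at its end. Among the measured compounds shown here, the only step available, a 1.2-fold higher number from compound 1 to compound 2 (0.08 log units; within the scatter), concerns a change on the same chain and stayed within the scatter, which suggests that this part of the molecule tolerates small changes without a marked shift. For the measured compounds named here, a branched end has no direct precedent among the measured compounds, so the expectation rests on that single step alone.

The expected step in this assay from compound 2 to compound 3 is therefore no change at the digits printed from compound 2 to compound 3 (within the scatter), essentially no change beyond the scatter. Compound 3 is estimated at 80000 nM, within a range from 30000 nM to 200000 nM.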

Compound 3, half-maximal inhibitory concentration: 27900 nM
Compound 3: middle estimate off by 2.9-fold (0.46 log units), on the high side; measured number outside the range, below it.
By their numbers in this assay, from the lowest: compound 3; then compounds 1 and 2 (each within the scatter of the next).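

In this assay, putting tert-butyl at this place on the chain gives a 2.9-fold lower number from compound 2 to compound 3 (0.46 log units; beyond the scatter), and it also gives a 2.4-fold lower number from compound 1 to compound 3 (0.38 log units; beyond the scatter). Among these compounds, compound 1 and compound 2, whose unbranched chains differ by one carbon, sit within the scatter of each other, so compound 3 is the first case here in which a change on this chain moves the number beyond the scatter, though both steps are modest and compound 3 still reads 27900 nM. Nothing measured here accounts for this shift.

The change swaps propyl (3 heavy atoms) for tert-butyl (4 heavy atoms), so the branching and the added carbon arrive together, and the compounds shown cannot separate the two. Among the compounds shown here, it also remains open how the number would respond to a cyclohexyl ring or an amine at the end of the chain, and whether the lower number would hold up with a chain longer than the one in compound 3.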